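A few compounds are considered here, and "the series" means these few. Any claim that something is new, unique, unknown or untested is made for them only; others in the source may bear on it.

Compound 1 `CCN(Cc1c(C(F)(F)F)nc2n(-c3c(C)cc(C)cc3C)c(Cl)cn12)CC1CC1` is the starting point. For the measured compounds named here, in an assay on cells for displacement of a labelled ligand from corticotropin-releasing factor receptor 1 (Homo sapiens), with a stated time of 100 min (on this read-out higher numbers stand for weaker inhibition and lower numbers for stronger inhibition), compound 1 gives 9 nM, the lowest of the two numbers measured so far. Going by the values given here, the only other measured compound, compound 2 `CCCCN(Cc1ccccc1)Cc1c(C(F)(F)F)nc2n(-c3c(C)cc(C)cc3C)c(Cl)cn12`, gives 130 nM in this assay, a gap from compound 1 that lies well beyond the scatter. Among the compounds with values here, no pair of measured compounds differs in a single place, so the two values can only be set side by side. Compound 3 `Cc1cc(C)c(-n2c(Cl)cn3c(CN(C)Cc4ccccc4)c(C(F)(F)F)nc23)c(C)c1` has not yet been measured. It departs from compound 1 by one change (benzyl(methyl)amino in place of (cyclopropylmethyl)(ethyl)amino on a saturated chain carbon bound to an aromatic carbon). Compound 2 shares the benzyl group but not the rest of that change. The author expects the step from compound 1 to compound 3 in this assay a 4.4-fold higher number from compound 1 to compound 3 (0.65 log units; beyond the scatter) to be a moderate rise, likely beyond the scatter. For compound 3 the expected value in this assay is 40 nM, within a range from 10 nM to 160 nM.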

Compound 3, inhibition constant: 160 nM
Compound 3: middle estimate off by 4.0-fold (0.60 log units), on the low side; the measured number falls inside the stated range.
By their numbers in this assay, from the lowest: compound 1; then compounds 2 and 3 (each within the scatter of the next).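

In this assay, benzyl(methyl)amino in place of (cyclopropylmethyl)(ethyl)amino on a saturated chain carbon bound to an aromatic carbon gives an 18-fold higher number from compound 1 to compound 3 (1.25 log units; beyond the scatter), the first single change read at this position, and it shows that the potency here depends strongly on the amine carried. Hydrogen in place of propyl on a saturated chain carbon bound to an amine nitrogen gives a 1.2-fold higher number from compound 2 to compound 3 (0.09 log units; within the scatter), so with benzyl present, this change in the other chain on the nitrogen makes no difference beyond the scatter. No measurement given here accounts for either step.

From the compounds shown here alone, compound 3 changes both substituents on the nitrogen at once, so it remains open whether the benzyl group alone tracks with the weaker number. Pairing benzyl with ethyl, or cyclopropylmethyl with methyl, would separate the two parts of the change.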